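This account rests on a few compounds, and the source may have more. Where it says the series, first, only, none or still open, it means among the compounds named here.

Compound 1 `C/C(=C\CC/C(C)=C/CC[C@@H]1[C@@]2(C)CCC(=O)C(C)(C)[C@H]2CC[C@@]1(C)O)CC/C=C(\C)C(=O)OCc1cn(C[C@@H]2O[C@H](n3ccc(=O)[nH]c3=O)C[C@H]2O)nn1`: 28100 nM
Compound 2 `C/C(=C\CC/C(C)=C/CC[C@@H]1[C@@]2(C)CCC(=O)C(C)(C)[C@H]2CC[C@@]1(C)O)CC/C=C(\C)C(=O)OCc1cn(-c2cccc(C)c2)nn1`: > 150000 nM
Compound 3 `C/C(=C\CC/C(C)=C/CC[C@@H]1[C@@]2(C)CCC(=O)C(C)(C)[C@H]2CC[C@@]1(C)O)CC/C=C(\C)C(=O)O`: > 150000 nM

Within the data shown here, in a functional assay on A549 cells (Homo sapiens) for antiproliferative activity, read by MTT assay, with a stated time of 48 h (a higher number here means a weaker inhibitor, a lower number a stronger inhibitor), compound 1 gives 28100 nM, the only numbered value among the three. For compound 2 the value > 150000 nM is a limit of the assay, not a number. For compound 3 the value > 150000 nM is likewise a limit. Among the measured compounds shown here, compound 2 therefore stands at the limit of > 150000 nM in this assay, at which 2 of the 3 values shown sit, with compound 1 the sole compound reported more strongly.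

Compound 4 `C/C(=C\CC/C(C)=C/CC[C@@H]1[C@@]2(C)CCC(=O)C(C)(C)[C@H]2CC[C@@]1(C)O)CC/C=C(\C)C(=O)OCc1cn(-c2ccccc2F)nn1` differs from compound 2 by 2-fluorophenyl in place of 3-methylphenyl on an aromatic nitrogen. For the measured compounds named here, no step between measured compounds covers this change, so there is no measured guide to its size. Compound 2 rests at a limit, and the step of a number no higher from compound 2 to compound 4 (the limit leaves the size open) is expected to be none beyond the scatter. Compound 4 is estimated at 150000 nM, between 40000 nM and 400000 nM, and is expected most likely to be reported again only as a limit.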

Compound 4, half-maximal inhibitory concentration: > 150000 nM
Compound 4 gave a limit, no number; the forecaster's own chance of this, stated with the estimate: 70%; the middle value lies on the limit itself.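

Compound 2 and compound 4 both rest at a limit in this assay, so no step can be read between them: the limit of > 150000 nM in this assay, at which 3 of the 4 values shown sit. On these data alone, how 2-fluorophenyl and 3-methylphenyl on the aromatic nitrogen compare in size of effect stays open.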